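Alkoxy variation in a three-compound series

The source may hold more compounds than are shown below. What is called first, only, known or untested is meant among the compounds shown, and "the series" means these compounds.

Measured compounds, all in a functional assay on PC-3 cells (Homo sapiens) for inhibition, read by MTT assay, with a stated time of 48 h; on this read-out higher numbers stand for weaker inhibition and lower numbers for stronger inhibition:
compound 1 `COc1cc(-c2nc3cc(/C=C4\SC(=O)NC4=O)ccc3[nH]2)cc(OC)c1OC` gives 12000 nM
compound 2 `COc1ccc(-c2nc3cc(/C=C4\SC(=O)NC4=O)ccc3[nH]2)cc1OC` gives 8720 nM
compound 3 `COc1cc(OC)c(-c2nc3cc(/C=C4\SC(=O)NC4=O)ccc3[nH]2)cc1OC` gives 6320 nM

Compound 2 stands second highest of the three numbers. Its two neighbours are reached by a 1.4-fold lower number from compound 1 to compound 2 (0.14 log units; within the scatter) and by a 1.4-fold lower number from compound 2 to compound 3 (0.14 log units; within the scatter); each of these is within the scatter, so the three compounds cannot be told apart on this read-out, and no ranking among them is claimed.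

Compound 4 `COc1cc(-c2nc3cc(/C=C4\SC(=O)NC4=O)ccc3[nH]2)ccc1OCC(C)C` differs from compound 2 by isopropyl in place of hydrogen on a saturated chain carbon bound to an oxygen on an aromatic ring. Neither measured step bears directly on this change: both concern a methoxy set against hydrogen on an aromatic carbon, and both were within the scatter. For the measured compounds named here, nothing measured here speaks to a methyl growing into an isobutyl on the oxygen of the aromatic ring; the only guidance is that small variations of the alkoxy pattern on this part of the shared core have so far left this assay unmoved.

The expectation for compound 4 is therefore no step beyond the scatter, a 1.0-fold lower number from compound 2 to compound 4 (0.01 log units; within the scatter), with the direction left open. Compound 4 is estimated at 8500 nM, within a range of 3000 nM to 25000 nM.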

Compound 4, half-maximal inhibitory concentration: 2980 nM
Compound 4: middle estimate off by 2.9-fold (0.46 log units), on the high side, and the stated range ends above it.
By their numbers in this assay, from the lowest: compound 4; then compounds 3, 2 and 1 (each within the scatter of the next).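

Replacing methoxy with isobutoxy, a change of methyl to isobutyl on the oxygen on the aromatic ring, moves this assay beyond the scatter, with a 2.9-fold lower number from compound 2 to compound 4 (0.47 log units; beyond the scatter), towards stronger inhibition, though the step is only modest. The two earlier steps, a 1.4-fold lower number from compound 1 to compound 2 (0.14 log units; within the scatter) and a 1.4-fold lower number from compound 2 to compound 3 (0.14 log units; within the scatter), exchanged methoxy and hydrogen on an aromatic carbon and stayed within the scatter, so the alkyl group carried on this oxygen is the only variation shown here to register on this read-out. No evidence on hand accounts for the step, and it stands as an observation from a single pair of compounds.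

With only one alkyl group shown besides methyl at this place, the step cannot be assigned to chain length or to branching, and ethoxy, n-butoxy or a longer straight chain would be needed to separate the two. Also open, as far as these compounds go, is whether the chain tolerates a terminal amine or carboxylic acid, and whether a cyclopentyl group on the same oxygen holds or extends the step.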